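The source may report more compounds than this note shows. Statements on the series, on what has been measured and on what is new or still open speak of the compounds shown alone.

Measured compounds in a functional assay on HEK293 cells for antagonist activity at cysteinyl leukotriene receptor 2 (Homo sapiens), read by fluorescence and calcium flux, with stated times of 30 min and 1 h; a lower number here means a stronger inhibitor, a higher number a weaker inhibitor:

- compound 1 `Cc1c(CCCC(=O)O)c2cccc(/C=C/c3ccc(OCCCCc4c(F)c(F)cc(F)c4F)cc3)c2n1CC(=O)O`: 3.7 nM
- compound 2 `Cc1c(CCCC(=O)O)c2cccc(/C=C/c3ccc(OCCCCc4c(F)cc(F)c(F)c4F)cc3)c2n1CC(=O)O`: 2.2 nM
- compound 3 `Cc1c(Cl)cccc1CCCCOc1ccc(C#Cc2cccc3c(CCCC(=O)O)c(C)n(CCC(=O)O)c23)cc1`: 22 nM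

Compound 2 carries the lowest of the three numbers shown, with compound 1 nearest to it and within the scatter, and compound 3 furthest from it and beyond the scatter. Compound 3 differs from compound 2 in several places at once, so its value says nothing about any single change.

Compound 4 `Cc1c(CCCC(=O)O)c2cccc(/C=C/c3ccc(OCCCCc4cc(F)c(F)c(F)c4F)cc3)c2n1CC(=O)O` is not yet measured. Relative to compound 2 the change is 2,3,4,5-tetrafluorophenyl in place of 2,3,4,6-tetrafluorophenyl on a saturated chain carbon, four bonds along the chain from an oxygen on an aromatic ring, a rearrangement of fluorine on the same ring. Within the data shown here, the one measured step that bears on such a rearrangement is a 1.7-fold lower number from compound 1 to compound 2 (0.23 log units; within the scatter), which stayed within the scatter. On that basis the expected step of a 1.4-fold higher number from compound 2 to compound 4 (0.13 log units; within the scatter) is also none beyond the scatter, with no direction favoured. Compound 4 is therefore estimated at 3 nM in this assay, with a range from 1.2 nM to 8 nM.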

Compound 4, half-maximal inhibitory concentration: 1.5 nM
The estimate for compound 4 lay 2.0-fold (0.30 log units) above the measured number, within the range that was stated.
By their numbers in this assay, from the lowest: compounds 4, 2 and 1 (each within the scatter of the next, the first and the last beyond it); then compound 3.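

In this assay, rearranging fluorine on the ring on a saturated chain carbon, four bonds along the chain from an oxygen on an aromatic ring, gives a 1.5-fold lower number from compound 2 to compound 4 (0.17 log units; within the scatter) and so does not separate 2,3,4,5-tetrafluorophenyl from 2,3,4,6-tetrafluorophenyl. The series also now shows a 2.5-fold lower number from compound 1 to compound 4 (0.39 log units; beyond the scatter) as the first rearrangement on this ring to pass the scatter, although 2,3,4,6-tetrafluorophenyl remains within the scatter of both other arrangements. Nothing available explains this difference.

Still open, going by these compounds, is whether four fluorines are needed at all, which plain phenyl or 4-fluorophenyl at this place would test. Also open, on these data alone, is whether the gap between 2,3,4,5-tetrafluorophenyl and 2,3,5,6-tetrafluorophenyl persists with a longer chain to the oxygen.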